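Aryl on the ring nitrogen: compound 1 to compound 3

The source may hold more compounds than are shown below. What is called first, only, known or untested is meant among the compounds shown, and "the series" means these compounds.

Compound 1 `CCOC(=O)c1ccc(-c2nn(Cc3ccc(Cl)cc3)c3ccccc23)cc1` has been tested in a functional assay on cells (Platelet, Homo sapiens) for inhibition; on this read-out lower numbers stand for stronger inhibition and higher numbers for weaker inhibition. In this assay compound 1 gives only a limit, > 10000 nM, not a number. Compound 2 `CCOC(=O)c1cccc(-c2nn(Cc3ccccc3)c3ccccc23)c1` likewise gives only a limit in this assay, > 10000 nM. Within the data shown here, both known values sit at the limit of > 10000 nM in this assay, at which 2 of the 2 values shown sit, so compound 1 has no position on a scale of numbers, and no measured step between compounds can be drawn from the two values. Compound 3 `CCOC(=O)c1ccc(-c2nn(-c3ccccc3)c3ccccc23)cc1` is not yet measured. It differs from compound 1 by phenyl in place of 4-chlorobenzyl on an aromatic nitrogen. With every value shown at the limit, the expected step is a step that the limit leaves unreadable from compound 1 to compound 3, which is none beyond the scatter. Compound 3 is therefore estimated at 15000 nM in this assay, with a range from 5000 nM to 60000 nM, and is most likely to be reported again as a limit rather than a number.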

Compound 3, half-maximal inhibitory concentration: > 10000 nM
Compound 3 gave a limit, no number; the forecaster's own chance of this, stated with the estimate: 85%; the middle value does not contradict the limit.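

In this assay compound 3 gives > 10000 nM as a limit and not a number, so no step can be read between compound 1 and compound 3: the limit of > 10000 nM in this assay, at which 3 of the 3 values shown sit. The compounds shown leave open how phenyl and 4-chlorobenzyl on the aromatic nitrogen compare, and whether any compound of this series gives a numerical value.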